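The compounds below may be only part of what the source reports. "The series", "measured", "known", "first", "only" and "open" are said of these compounds alone.

Compound 1 `COc1cc(/C=C/C(=O)C2=C(/C=C/c3ccc(O)c(OC)c3)NC(=O)NC2c2ccc(O)cc2)ccc1O` stands highest of the two numbers measured in a functional assay, with a stated time of 20 min, tested at 50 uM; on this read-out higher numbers stand for a stronger effect at the one concentration tested and lower numbers for a weaker effect: compound 1 gives 86.2%. Compound 2 `COc1cc(/C=C/C(=O)C2=C(/C=C/c3ccc(O)c(OC)c3)NC(=O)NC2c2c(Cl)cccc2Cl)ccc1O` gives 44.2%. That single step, a number 42 percentage points lower from compound 1 to compound 2 (beyond the scatter), is the only measured one that bears on the new compound. Compound 3 `COc1cc(/C=C/C(=O)C2=C(/C=C/c3ccc(O)c(OC)c3)NC(=O)NC2c2ccccc2Cl)ccc1O` differs from compound 1 by 2-chlorophenyl in place of 4-hydroxyphenyl on a saturated ring carbon. Compound 2 carries a 2,6-dichlorophenyl in the same place, and compound 3 carries a 2-chlorophenyl, so a drop is expected in this assay, though perhaps a smaller one. The expected step is a number 28.2 percentage points lower from compound 1 to compound 3 (beyond the scatter). For compound 3 the estimate is 58%, within a range from 40% to 76%.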

Compound 3, a percentage reported as activity, at one concentration (the size of the read-out at that concentration, not a potency): 56%
The estimate for compound 3 lay 2 percentage points above the measured number; the measured number falls inside the stated range.
By their numbers in this assay, from the lowest: compound 2; then compound 3; then compound 1.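

In this assay, the 2-chlorophenyl group already accounts for much of the loss seen with 2,6-dichlorophenyl, giving a number 30.2 percentage points lower from compound 1 to compound 3 (beyond the scatter). The second chloro still matters, since hydrogen in its place gives a number 11.8 percentage points higher from compound 2 to compound 3 (beyond the scatter), so the number at this position changes with the aromatic substitution in graded steps across these three compounds. No measurement shown here explains either step. Compound 3 both loses the hydroxyl and gains a chloro, so the two changes remain tangled. A plain phenyl group at this position would help separate them.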